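The compounds below may be only part of what the source reports. "The series", "measured", "known", "first", "only" and "open" are said of these compounds alone.

In an ADME assay for permeability (a higher number here means that the compound crosses the layer faster, a lower number that the compound crosses the layer more slowly), compound 1 (`CNC(=O)c1cc(C(=O)N[C@H]2CC[C@H](OC)CC2)c([C@@H](C)c2ccccc2)o1`) gives 303 nm/s and compound 2 (`CNC(=O)c1cc(C(=O)N[C@H]2CC[C@H](O)CC2)c([C@@H](C)c2ccc(C)cc2)o1`) gives 108 nm/s. Compound 2 therefore holds the lower of the two numbers, and the gap between them lies beyond the scatter. Compound 3 (`CNC(=O)c1cc(C(=O)N[C@H]2CC[C@H](O)CC2)c([C@@H](C)c2ccccc2)o1`) is compound 2 with hydrogen in place of methyl on an aromatic carbon, so that 4-methylphenyl becomes phenyl: hydrogen in place of methyl on an aromatic carbon. Within the data shown here, no two measured compounds differ in one place only, so no measured step shows what this swap does in this assay. With so little to go on, the best guide is the number for compound 2, 108 nm/s, and no change beyond the scatter is expected. The expected step of a 1.2-fold higher number from compound 2 to compound 3 (0.06 log units; within the scatter) is small, perhaps a slight rise. Compound 3 is estimated at 125 nm/s, with an expected range of 65 nm/s to 230 nm/s.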

Compound 3, apparent permeability in the ADME assay: 42 nm/s
Estimate against measurement, compound 3: 3.0-fold (0.47 log units) above, outside the stated range (below it).
By their numbers in the ADME assay, from the lowest: compound 3; then compound 2; then compound 1.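

In the ADME assay, one carbon on the aromatic ring is enough to move the number, as the change from 4-methylphenyl to phenyl shows: a 2.6-fold lower number from compound 2 to compound 3 (0.41 log units; beyond the scatter). The methyl on the oxygen counts in the ADME assay as well, since hydrogen in its place gives a 7.2-fold lower number from compound 1 to compound 3 (0.86 log units; beyond the scatter), which leaves compound 3, with neither methyl, lowest of the three. In a physicochemical assay for solubility, read by HPLC, in simulated intestinal fluid, with a stated time of 16 h, at pH 6.5 (a lower number here means a less soluble compound, a higher number a more soluble compound), compound 2 gives > 1000 ug/mL, which is a limit of the assay and not a number. In the physicochemical assay compound 3 gives 827 ug/mL. In the physicochemical assay the aromatic swap reads only as an at least 1.2-fold lower number from compound 2 to compound 3 (0.08 log units; that floor lies within the scatter), and that step rests on a limit rather than a number: the limit of > 1000 ug/mL in the physicochemical assay, at which 1 of the 2 values shown sits.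

Still open, from the compounds shown here alone, is whether another group in the same place on the aromatic ring, such as chlorine, or a longer chain on the oxygen, such as ethyl, would move the number as methyl does. Also open, going by these compounds, is whether the two methyl steps would add up in a single compound.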